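Mirror image at one ring carbon: what happens to stability?

The source may hold more compounds than are shown below. What is called first, only, known or untested is meant among the compounds shown, and "the series" means these compounds.

Compound 1 (`c1ccc2c(c1)CN[C@@H](CN(CC1CCNCC1)[C@H]1CCCc3cccnc31)C2`) gives 65%
Compound 2 (`c1ccc2c(c1)CN[C@H](CN(CCCN1CCNCC1)[C@H]1CCCc3cccnc31)C2`) gives 88%

In an ADME assay on microsomes from liver (Rattus norvegicus) for metabolic stability, read by LC-MS, with a stated time of 10 min, tested at 0.5 uM (a higher number here means that more of the compound is left, a lower number that less of the compound is left), compound 2 stands highest of the two at 88% and compound 1 lies lower by a gap beyond the usual scatter. Compound 3 (`c1ccc2c(c1)CN[C@@H](CN(CCCN1CCNCC1)[C@H]1CCCc3cccnc31)C2`) keeps the atoms and bonds of compound 2 (the two compounds have the same atoms and bonds and differ only in configuration as drawn: 1 of 2 stereo elements differ; a stereocentre at a saturated ring carbon is drawn S in compound 2 and R in compound 3): a stereocentre at a saturated ring carbon is drawn S in compound 2 and R in compound 3. For the measured compounds named here, no two measured compounds differ in one place only, so nothing yet shows how far such a change moves the number in this assay. With compound 2 at 88% little room remains upward, so a small loss seems likelier than a gain. The expected a number 8 percentage points lower from compound 2 to compound 3 (within the scatter) is a modest fall that may stay within the scatter. Compound 3 is estimated at 80% (expected range 62% to 95%).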

Compound 3, percent of the compound remaining: 100%
Beside the measured number, compound 3's estimate is 20 percentage points below it; the measured number lies above the stated range.
By their numbers in this assay, from the lowest: compound 1; then compound 2; then compound 3.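

In this assay the mirror-image change at the saturated ring carbon is enough by itself to shift the number beyond the scatter, giving a number 12 percentage points higher from compound 2 to compound 3 (beyond the scatter) in favour of the form drawn R. No other structural change can account for this step: the fact that compounds 2 and 3 differ only in the configuration as drawn.

The side chain also matters, since 2-(piperazin-1-yl)ethyl in place of piperidin-4-yl on a saturated chain carbon bound to an amine nitrogen gives a number 35 percentage points higher from compound 1 to compound 3 (beyond the scatter) and is a large step.

From the compounds shown here alone, whether the form drawn R also keeps more with the piperidin-4-yl group remains open, as does the effect of the second stereocentre. Going by these compounds, it is also open how a morpholine or a longer chain in place of the 2-(piperazin-1-yl)ethyl group would behave in this assay under the same conditions.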